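Carboxylic acid exchanged for a sulfone on the chain

This account rests on a few compounds, and the source may have more. Where it says the series, first, only, none or still open, it means among the compounds named here.

Compound 3 `CCc1cc(C(C)=O)c(O)cc1OCCCCCC(C)(C)C(=O)O` stands highest of the three compounds measured in an assay on isolated protein for inhibition of leukotriene B4 receptor 1 (Homo sapiens), tested at 10 uM (a higher number here means more inhibition at the concentration tested (going by the name of the read-out), a lower number less inhibition), where compound 3 gives 104%. In this assay compound 1 `CCc1cc(C(C)=O)c(O)cc1OCCCC(C)(C)C#N` gives 85%, and compound 2 `CCc1cc(C(C)=O)c(O)cc1OCCCCC(C)(C)C#N` gives 79%. The step of a number 6 percentage points lower from compound 1 to compound 2 (within the scatter) alters only the length of the chain. The two steps that lead to compound 3, a number 19 percentage points higher from compound 1 to compound 3 (beyond the scatter) and a number 25 percentage points higher from compound 2 to compound 3 (beyond the scatter), both exchange a nitrile for a carboxylic acid and both raise the number beyond the scatter. Compound 4 `CCc1cc(C(C)=O)c(O)cc1OCCCCCCS(C)(=O)=O` differs from compound 3 in this way: (methylsulfonyl)methyl in place of 1-carboxy-1-methylethyl on a saturated chain carbon, five bonds along the chain from an oxygen on an aromatic ring. For the measured compounds named here, no measured step shows a carboxylic acid replaced by a methylsulfonyl group, so the closest guide is that the two compounds lacking the carboxylic acid, compound 1 and compound 2, sit lower than compound 3 by the steps just named. A downward step of similar size is therefore expected, a number 24 percentage points lower from compound 3 to compound 4 (beyond the scatter). Compound 4 is estimated at 80% in this assay, with a range from 60% to 100%.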

Compound 4, a percentage reported as inhibition, at one concentration (the size of the read-out at that concentration, not a potency): 99%
Beside the measured number, compound 4's estimate is 19 percentage points below it; low and high end bracket the measured number.
By their numbers in this assay, from the lowest: compounds 2 and 1 (each within the scatter of the next); then compounds 4 and 3 (each within the scatter of the next).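

In this assay, the exchange of the 1-carboxy-1-methylethyl end for (methylsulfonyl)methyl, five bonds along the chain from an oxygen on an aromatic ring, gives a number 5 percentage points lower from compound 3 to compound 4 (within the scatter), so among these compounds a carboxylic acid is not needed for a number at this level. The earlier compounds shown here without the acid both ended in a nitrile and sat lower, and the sulfone now stands clear of both, with a number 20 percentage points higher from compound 2 to compound 4 (beyond the scatter) and a number 14 percentage points higher from compound 1 to compound 4 (beyond the scatter), so the lower numbers go with the nitrile compounds and not with every end lacking the acid. Nothing available explains why the sulfone holds the number in this way.

On these data alone, whether a sulfonamide or a primary amide at the chain end would do the same remains open. So does whether the methylsulfonyl group would keep this number on a shorter or longer chain.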